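The compounds below may be only part of what the source reports. "The series", "measured", "known", "first", "only" and "open" are said of these compounds alone.

In a functional assay on SK-BR-3 cells (Homo sapiens) for antiproliferative activity (on this read-out higher numbers stand for weaker inhibition and lower numbers for stronger inhibition), compound 1 `CC(=O)Oc1ccc(C(=O)Nc2cc3ccc(OCC4CCCN(C)C4)c(C)c3oc2=O)cc1CC=C(C)C` gives 740 nM and compound 2 `CC(=O)Oc1ccc(C(=O)Nc2cc3ccc(OCCC4CCCCN4)c(C)c3oc2=O)cc1CC=C(C)C` gives 640 nM as its value, so compound 2 stands level with compound 1 within the scatter. Compound 3 `CC(=O)Oc1ccc(C(=O)Nc2cc3ccc(OCC4CCCNC4)c(C)c3oc2=O)cc1CC=C(C)C` carries piperidin-3-yl in place of (piperidin-2-yl)methyl on a saturated chain carbon bound to an oxygen on an aromatic ring. Within the data shown here, the one measured step that bears on this change, a 1.2-fold lower number from compound 1 to compound 2 (0.06 log units; within the scatter), stays within the scatter, so no step beyond the scatter is expected in this assay here. The expected step is a 1.1-fold higher number from compound 2 to compound 3 (0.03 log units; within the scatter) in size. The estimate for compound 3 is 680 nM with an expected range from 320 nM to 1400 nM overall.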

Compound 3, half-maximal inhibitory concentration: 620 nM
Compound 3: the middle estimate sits 1.1-fold (0.04 log units) above what was measured, within the range that was stated.
By their numbers in this assay, from the lowest: compounds 3, 2 and 1 (each within the scatter of the next).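

In this assay the step of a 1.0-fold lower number from compound 2 to compound 3 (0.01 log units; within the scatter) comes with piperidin-3-yl in place of (piperidin-2-yl)methyl on a saturated chain carbon bound to an oxygen on an aromatic ring. The step of a 1.2-fold lower number from compound 1 to compound 3 (0.08 log units; within the scatter) adds a direct comparison for hydrogen in place of methyl on an amine nitrogen in a ring, and neither change goes beyond the scatter. No measurement at hand offers an explanation for this result. On these data alone, it remains open whether a morpholine ring or an open-chain dimethylamino group at this position would stay level with these three compounds in this assay as well.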